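A few compounds are considered here, and "the series" means these few. Any claim that something is new, unique, unknown or untested is made for them only; others in the source may bear on it.

Of the compounds shown here, three have been measured in a functional assay on HeLa cells (Homo sapiens) for inhibition, read by MTT assay, with a stated time of 24 h; a lower number here means a stronger inhibitor, a higher number a weaker inhibitor. Compound 1 `CO/N=C1\C[C@@H](c2ccc(F)cc2)N[C@@H](c2ccc(F)cc2)[C@@H]1C` gives 49200 nM. Compound 3 `CO/N=C1\C[C@@H](c2ccc(F)cc2)N(C)[C@@H](c2ccc(F)cc2)[C@@H]1C` differs from compound 1 by methyl in place of hydrogen on an amine nitrogen in a ring, and in this assay compound 3 gives 40700 nM, so that the step of a 1.2-fold lower number from compound 1 to compound 3 (0.08 log units; within the scatter). Compound 2 `CO/N=C1\C[C@@H](c2ccc(OC)cc2)N[C@@H](c2ccc(OC)cc2)[C@@H]1C` has a different core; the difference between the two cores is not broken down here. In this assay compound 2 gives 154000 nM, the highest of the three numbers.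

Compound 4 `CO/N=C1\C[C@@H](c2ccc(OC)cc2)N(C)[C@@H](c2ccc(OC)cc2)[C@@H]1C` has not yet been measured. It differs from compound 2 by methyl in place of hydrogen on an amine nitrogen in a ring. The surroundings are not identical: in compound 1 the amine nitrogen sits next to two ring atoms that each bear a 4-fluorophenyl group, in compound 2 next to two ring atoms that each bear a 4-methoxyphenyl group, so this is the same kind of change rather than the same one. A step of a 1.2-fold lower number from compound 2 to compound 4 (0.07 log units; within the scatter) is expected because a 1.2-fold lower number from compound 1 to compound 3 (0.08 log units; within the scatter) lay within the scatter. Compound 4 is therefore estimated at 130000 nM, with a range from 60000 nM to 300000 nM.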

Compound 4, half-maximal inhibitory concentration: 80600 nM
Estimate against measurement, compound 4: 1.6-fold (0.21 log units) above; low and high end bracket the measured number.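

In this assay, the new step for methyl in place of hydrogen on an amine nitrogen in a ring is a 1.9-fold lower number from compound 2 to compound 4 (0.28 log units; within the scatter), and it can be set beside the earlier step for the same change on the core of compound 1: the same change on two cores in this assay, a 1.2-fold lower number (0.08 log units; within the scatter) from compound 1 to compound 3 and a 1.9-fold lower number (0.28 log units; within the scatter) from compound 2 to compound 4, 1.6-fold (0.20 log units) apart, within the scatter of two such steps

On these two cores, then, the change behaves alike: neither step leaves the scatter, and the two steps cannot be told apart. This does not show that the methyl is without any effect, since a small real effect could hide inside the scatter, and two cores are too few to predict what the same change would do on a third.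

The compounds shown carry only hydrogen or methyl on the amine nitrogen, so the result of a longer chain such as ethyl, or of an acetyl group, in that place stays open. The aryl groups are likewise limited to 4-fluorophenyl and 4-methoxyphenyl, which leaves open how the change would behave with a plain phenyl or a 4-chlorophenyl group.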